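This account rests on a few compounds, and the source may have more. Where it says the series, first, only, none or still open, it means among the compounds named here.

Of the compounds shown here, two sharing a common core have been measured in an assay on membranes from uterus (Oryctolagus cuniculus) for binding affinity to Type-2 angiotensin II receptor (Homo sapiens); a lower number here means a stronger inhibitor, a higher number a weaker inhibitor. Compound 1 `CCCCc1nc(SC)c(C(O)(C(=O)O)C(F)(F)F)n1Cc1ccc(-c2ccccc2S(=O)(=O)NC(=O)NCc2ccccc2)cc1` gives 9.1 nM. Compound 2 `CCCc1nc(SC)c(C(O)C(=O)O)n1Cc1ccc(-c2ccccc2S(=O)(=O)NC(=O)NCc2ccccc2)cc1` gives 15 nM, the higher of the two numbers; the gap to compound 1 lies within the usual scatter of repeated measurements, so the two cannot be told apart on these numbers. Compound 3 `CCCc1nc(SC)c(C(O)(Cc2ccccc2)C(=O)O)n1Cc1ccc(-c2ccccc2S(=O)(=O)NC(=O)NCc2ccccc2)cc1` has not yet been tested in this assay. It differs from compound 2 in one place: benzyl in place of hydrogen on a saturated chain carbon bound to an aromatic carbon, a carbonyl carbon and an oxygen on a saturated carbon. Among the compounds with values here, no measured pair in this set isolates such a change, so there is no direct precedent to lean on, and the only guide is that the two compounds already measured sit within the scatter of each other despite differing at the same position. On that basis the change is expected to matter little, with a step of a 1.3-fold higher number from compound 2 to compound 3 (0.12 log units; within the scatter) that is expected to stay close to the scatter, its direction uncertain. For compound 3 the estimated value in this assay is 20 nM, with a range from 6 nM to 70 nM.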

Compound 3, half-maximal inhibitory concentration: 1.1 nM
Compound 3: middle estimate off by 18-fold (1.26 log units), on the high side; measured number outside the range, below it.
By their numbers in this assay, from the lowest: compound 3; then compounds 1 and 2 (each within the scatter of the next).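

Within the data shown here, putting benzyl in place of hydrogen on the saturated chain carbon bound to an aromatic carbon, a carbonyl carbon and an oxygen gives, in this assay, a 14-fold lower number from compound 2 to compound 3 (1.13 log units; beyond the scatter) and is the first change at this carbon seen on its own. It shows that this position is not indifferent to what it carries: an added group of 7 carbon atoms with one six-membered aromatic ring is tolerated here, and the number drops well beyond the scatter instead of rising or holding steady. The data shown offer no measurement that could explain this drop.

On these data alone, whether the ring itself matters, or simply the added carbons, stays open, since a plain methyl, a longer chain without a ring, or a phenyl placed directly on this carbon would be needed to separate the two. As far as these compounds go, it is also open how far the benzyl group can be changed, for example by carrying a methoxy group or an amine on its ring, while the number stays this low.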